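The source may report more compounds than this note shows. Statements on the series, on what has been measured and on what is new or still open speak of the compounds shown alone.

Compound 1 `Cn1nc(N)c2c(=O)[nH]c(-c3ccccc3)cc21` is the starting point: in an assay on isolated protein for inhibition of MAP kinase-activated protein kinase 5 (Homo sapiens), read by mobility shift assay, tested at 30 uM (a lower number here means less inhibition, a higher number more inhibition at the concentration tested (going by the name of the read-out)), compound 1 gives 11%. Compound 2 `CC(=O)Nc1nn(C)c2cc(-c3ccccc3)[nH]c(=O)c12` carries an acetyl group where compound 1 carries a hydrogen on a nitrogen of an aromatic ring; in this assay compound 2 gives 3%. The step of a number 8 percentage points lower from compound 1 to compound 2 (within the scatter) lies within the usual scatter, so the two compounds cannot be told apart on these numbers, and compound 2 simply sits at the end of a pair of weak results.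

Compound 3 `CC(=O)Nc1nn(C)c2cc(-c3ccc(N4CCN(C)CC4)cc3)[nH]c(=O)c12` differs from compound 2 by 4-methylpiperazin-1-yl in place of hydrogen on an aromatic carbon. Among the measured compounds shown here, the only measured step concerns a different part of the molecule, so nothing measured so far bears directly on this change, and no step beyond the scatter is expected in this assay. Compound 3 is therefore expected to give about 6%, in a range from -8% to 25%, which means an estimated step of a number 3 percentage points higher from compound 2 to compound 3 (within the scatter).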

Compound 3, a percentage reported as inhibition, at one concentration (the size of the read-out at that concentration, not a potency): 6%
For compound 3 middle estimate and measured number coincide at the digits printed; the range from low to high includes it.
By their numbers in this assay, from the lowest: compounds 2, 3 and 1 (each within the scatter of the next).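

Putting 4-methylpiperazin-1-yl in place of hydrogen on an aromatic carbon, para to a large group, gives a number 3 percentage points higher from compound 2 to compound 3 (within the scatter) in this assay. Among the compounds shown here, this is the first information about this part of the molecule, as the earlier step concerned the acetyl group on nitrogen: a ring group of 7 heavy atoms can stand at this place, yet compound 3 at 6% cannot be told apart from compound 2 in this assay. Nothing available explains this result.

Going by these compounds, it remains open whether a different group at the same place, such as a carboxylic acid, a morpholin-4-yl ring or a simple amine, would give a step beyond the scatter. On these data alone, it is also open whether 4-methylpiperazin-1-yl would behave the same way on compound 1, which lacks the acetyl group.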